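Cyano in Place of Acetamido on a Sulfonyl Hydrazide

The source may report more compounds than this note shows. Statements on the series, on what has been measured and on what is new or still open speak of the compounds shown alone.

Three measured compounds share one core and differ only on the ring attached to the hydrazide. In an assay for inhibition of Indoleamine 2,3-dioxygenase 1 (Homo sapiens), read by spectrophotometry, with stated times of 1 h and 4 h (a lower number here means a stronger inhibitor, a higher number a weaker inhibitor), compound 1 `CC(=O)Nc1ccc(S(=O)(=O)NNc2ccccc2)cc1` gives 71 nM. Compound 2 `CC(=O)Nc1ccc(S(=O)(=O)NNc2ccc(C)cc2)cc1` gives 51 nM, and compound 3 `CC(=O)Nc1ccc(S(=O)(=O)NNc2ccc(Br)cc2)cc1` gives 130 nM, the highest of the three numbers shown, although a 1.8-fold higher number from compound 1 to compound 3 (0.26 log units; within the scatter) stays within the scatter while a 2.5-fold higher number from compound 2 to compound 3 (0.41 log units; beyond the scatter) is a modest step beyond it. Compound 4 `N#Cc1ccc(S(=O)(=O)NNc2ccc(Br)cc2)cc1` differs from compound 3 in cyano in place of acetamido on an aromatic carbon. For the measured compounds named here, none of the measured steps touches this part of the molecule, so no measured step bears directly on the change. Compound 4 is therefore expected to land near compound 3, with an estimated step of a 1.5-fold higher number from compound 3 to compound 4 (0.19 log units; within the scatter) and a wide range. Compound 4 is estimated at 200 nM, between 60 nM and 700 nM.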

Compound 4, half-maximal inhibitory concentration: 176 nM
For compound 4 the middle estimate is 1.1-fold (0.06 log units) above the measured one; measured number inside the range.
By their numbers in this assay, from the lowest: compounds 2, 1, 3 and 4 (each within the scatter of the next, the first and the last beyond it).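

At the position para to a large group, the first change away from the ring on the hydrazide, a 1.4-fold higher number from compound 3 to compound 4 (0.13 log units; within the scatter) is what cyano in place of acetamido gives in this assay. With the bromo ring kept, the number therefore stays within the scatter when the acetamido group gives way to a cyano with fewer heavy atoms and no hydrogen-bond donor. No measurement shown here explains this result.

As far as these compounds go, whether cyano behaves the same way with the methyl or the unsubstituted ring remains open. So does the outcome with an amine or a carboxylic acid at this position.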